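This account rests on a few compounds, and the source may have more. Where it says the series, first, only, none or still open, it means among the compounds named here.

Measured so far in a functional assay on MDA-MB-231 cells (Homo sapiens) for inhibition, read by MTT assay; on this read-out higher numbers stand for weaker inhibition of growth and lower numbers for stronger inhibition of growth:
Compound 1 `CC1=C(/C=C/C(C)=C/C=C/C(C)=C\C(=O)Nc2ccccc2)C(C)(C)CCC1n1ccnc1` gives 1740 nM
Compound 2 `CC1=C(/C=C/C(C)=C/C=C/C(C)=C\C(=O)NCc2cccc(F)c2)C(C)(C)CCC1n1ccnc1` gives 1650 nM
Compound 3 `CC1=C(/C=C/C(C)=C/C=C/C(C)=C\C(=O)NCc2ccc(O)cc2)C(C)(C)CC=C1c1cncnc1` gives 11500 nM

Compound 3 carries the highest of the three numbers, and its distance from both compound 1 and compound 2 lies beyond the scatter. Compound 4 `CC1=C(/C=C/C(C)=C/C=C/C(C)=C\C(=O)Nc2ccccc2)C(C)(C)CC=C1c1cncnc1` keeps the core of compound 3 and makes one change, (phenyl in place of 4-hydroxybenzyl on an amide-type nitrogen), which is phenyl in place of 4-hydroxybenzyl on an amide-type nitrogen. Among the compounds with values here, only one measured step concerns this nitrogen, a 1.1-fold lower number from compound 1 to compound 2 (0.02 log units; within the scatter), and it was made on a different core with a different benzyl group. Within the data shown here, no measured step removes 4-hydroxybenzyl. Compound 1 shares the phenyl of compound 4 but differs from compound 3 at the core as well, so its lower number cannot be credited to the phenyl alone. That leaves grounds for expecting only a small move toward a lower number in this assay, near the edge of the scatter. The expected step is a 1.8-fold lower number from compound 3 to compound 4 (0.25 log units; within the scatter) and it remains uncertain. Compound 4 is estimated at 6500 nM, with a range from 2500 nM to 16000 nM as its expected span.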

Compound 4, concentration for 50% growth inhibition: 26900 nM
Compound 4: the middle estimate sits 4.1-fold (0.62 log units) below what was measured; the measured number lies above the stated range.
By their numbers in this assay, from the lowest: compounds 2 and 1 (each within the scatter of the next); then compound 3; then compound 4.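

On the core shared by compound 3 and compound 4, the group on the amide-type nitrogen does register in this assay: the listed change gives a 2.3-fold higher number from compound 3 to compound 4 (0.37 log units; beyond the scatter), a modest step toward weaker inhibition of growth. Within the data shown here, the only earlier step at this nitrogen, a 1.1-fold lower number from compound 1 to compound 2 (0.02 log units; within the scatter), stayed within the scatter, on another core and with 3-fluorobenzyl as the incoming group, so this position had not yet been seen to move the number. Nothing available accounts for the direction of this step.

Phenyl and 4-hydroxybenzyl differ in both the hydroxyl and the carbon linking the ring to the nitrogen, so the step cannot be assigned to either, and a plain benzyl group on this core would separate the two. On these data alone, it also remains open whether the same change would move the number on the core of compound 1.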